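A few compounds are considered here, and "the series" means these few. Any claim that something is new, unique, unknown or untested is made for them only; others in the source may bear on it.

Of the compounds shown here, two have been tested so far in an ADME assay (liver) for metabolic stability, with Liver microsome (Rattus norvegicus) as the target, using microsomes and NADPH, with a stated time of 30 min, at 37 degrees C, tested at 1 uM; a lower number here means slower removal, a higher number faster removal of the compound. Compound 1 `Nc1ccc(S(=O)(=O)c2ccc(-c3ccc(C(O)(C(F)(F)F)C(F)(F)F)cn3)cc2)cn1` reads < 14 mL.min-1.g-1, which is a limit of the assay and not a number. Among the measured compounds shown here, compound 2 `CC(O)(c1ccc(-c2ccc(S(=O)(=O)c3ccc(N)nc3)nc2NC2CC2)nc1)C(F)(F)F` gives 43 mL.min-1.g-1, the only true number available in this assay. Compound 3 `CC(O)(c1ccc(-c2ccc(S(=O)(=O)c3ccc(N)nc3)nc2Nc2cccnc2)nc1)C(F)(F)F` keeps the core of compound 2 and carries pyridin-3-yl in place of cyclopropyl on a nitrogen on an aromatic ring. The cyclopropylamino group thus becomes a (pyridin-3-yl)amino group. For the measured compounds named here, no measured pair in this set shows such a change, so the expectation rests on compound 2 and its 43 mL.min-1.g-1 alone. The expected step is a 1.2-fold lower number from compound 2 to compound 3 (0.09 log units; within the scatter), a small fall that is not expected to go beyond the usual scatter, and either direction remains possible. For compound 3 the estimated value is 35 mL.min-1.g-1, with an expected range of 15 mL.min-1.g-1 to 85 mL.min-1.g-1.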

Compound 3, intrinsic clearance in microsomes: 142 mL.min-1.g-1
Beside the measured number, compound 3's estimate is 4.1-fold (0.61 log units) below it; measured number outside the range, above it.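

In this assay, the first change read at this position, pyridin-3-yl in place of cyclopropyl on a nitrogen on an aromatic ring, gives a 3.3-fold higher number from compound 2 to compound 3 (0.52 log units; beyond the scatter). The group carried on this nitrogen therefore matters to the read-out: here the step lies beyond the scatter, and it runs towards faster removal, so swapping cyclopropylamino for (pyridin-3-yl)amino does not leave the number in place. Nothing among the data shown gives a reason for this rise.

One step cannot tell whether the rise goes with the aromatic ring as such or with its ring nitrogen, and a phenyl group on the same nitrogen would separate the two. Going by these compounds, how a small alkyl group such as methyl, or a pyridin-4-yl group, would read at this place also remains open.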